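Anilino aryl variation on the shared core

A few compounds are considered here, and "the series" means these few. Any claim that something is new, unique, unknown or untested is made for them only; others in the source may bear on it.

Measured compounds:
compound 1 `N#Cc1c(Nc2ccccc2Cl)nc(SCc2cn(Cc3ccccc3Cl)nn2)nc1-c1ccccc1` gives 8350 nM
compound 2 `N#Cc1c(Nc2cccc(Cl)c2)nc(SCc2cn(Cc3ccccc3Cl)nn2)nc1-c1ccccc1` gives 3590 nM
compound 3 `N#Cc1c(Nc2ccc(F)cc2)nc(SCc2cn(Cc3ccccc3Cl)nn2)nc1-c1ccccc1` gives 5340 nM

All three numbers come from a functional assay on B16-F10 cells (Mus musculus) for inhibition, read by MTT assay, with a stated time of 72 h; on this read-out lower numbers stand for stronger inhibition and higher numbers for weaker inhibition. Compound 3 stands second highest of the three; its nearest neighbour is compound 2 and its furthest compound 1, both within the scatter: a 1.5-fold higher number from compound 2 to compound 3 (0.17 log units; within the scatter) and a 1.6-fold lower number from compound 1 to compound 3 (0.19 log units; within the scatter). Among the measured compounds shown here, only one step exceeds the scatter: a 2.3-fold lower number from compound 1 to compound 2 (0.37 log units; beyond the scatter).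

Compound 4 `Cc1ccc(Nc2nc(SCc3cn(Cc4ccccc4Cl)nn3)nc(-c3ccccc3)c2C#N)cc1` differs from compound 3 by methyl in place of fluoro on an aromatic carbon. For the measured compounds named here, no measured step exchanges fluoro for methyl; the three measured steps all alter the aryl group on the nitrogen and are modest or within the scatter. In this assay no step beyond the scatter is therefore expected for compound 4. The expected step is a 1.1-fold lower number from compound 3 to compound 4 (0.03 log units; within the scatter). Compound 4 is estimated at 5000 nM, within 2500 nM to 10000 nM.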

Compound 4, half-maximal inhibitory concentration: 3390 nM
Compound 4: the middle estimate sits 1.5-fold (0.17 log units) above what was measured; measured number inside the range.
By their numbers in this assay, from the lowest: compounds 4, 2, 3 and 1 (each within the scatter of the next, the first and the last beyond it).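

In this assay, swapping 4-fluorophenyl for 4-methylphenyl on the nitrogen leaves the reading within the scatter (a 1.6-fold lower number from compound 3 to compound 4 (0.20 log units; within the scatter)), and 4-methylphenyl also stays within the scatter of 3-chlorophenyl (a 1.1-fold lower number from compound 2 to compound 4 (0.02 log units; within the scatter)). Against 2-chlorophenyl the step is beyond the scatter but modest (a 2.5-fold lower number from compound 1 to compound 4 (0.39 log units; beyond the scatter)), so compound 1 now stands apart from both compound 2 and compound 4, while compound 3 remains within the scatter of all three. No measurement at hand accounts for these numbers.

Going by these compounds, whether this narrow spread holds for other groups at this ring position, such as methoxy, an amine or a carboxylic acid, stays open. Also open, on these data alone, is whether a methyl in the 2-position of the phenyl ring would match the reading of 2-chlorophenyl.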